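The source may hold more compounds than are shown below. What is called first, only, known or untested is meant among the compounds shown, and "the series" means these compounds.

Compound 1 `CCCCc1cc2c(=O)c(C#N)c[nH]c2cc1OCCOc1ccccc1` was tested in an ADME assay on J774 cells (Mus musculus) for cytotoxicity; a higher number here means that more compound is needed for the effect, a lower number that less compound is needed. There compound 1 gives > 20000 nM, which is a limit of the assay rather than a number, so compound 1 stands at the limit of > 20000 nM in this assay, at which 1 of the 2 values shown sits. In this assay compound 2 `COC(=O)c1c[nH]c2ccc(OC)cc2c1=O` gives 6180 nM. Compound 3 `CCCCc1cc2c(=O)c(Br)c[nH]c2cc1OCCOc1ccccc1` has not yet been measured in this assay. It differs from compound 1 in one place: bromo in place of cyano on an aromatic carbon. For the measured compounds named here, no comparable step has been measured, and the change is expected to move the value by nothing beyond the usual scatter. Compound 3 is therefore estimated at 20000 nM in this assay, with a range from 8000 nM to 50000 nM, which means a number no higher from compound 1 to compound 3 (the limit leaves the size open).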

Compound 3, half-maximal effective concentration: 8070 nM
Compound 3: middle estimate off by 2.5-fold (0.39 log units), on the high side, and the stated range covers the measured number.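

Replacing cyano with bromo on this aromatic carbon gives an at least 2.4-fold lower number from compound 1 to compound 3 (0.39 log units; beyond the scatter) in this assay, so the read-out responds to a change at this position of the shared core. Compound 1 stays at a limit of the assay, so only one side of this step is fixed and its full size remains open: the limit of > 20000 nM in this assay, at which 1 of the 3 values shown sits.

The two compounds alone cannot show whether bromo or the absence of cyano accounts for the step. On these data alone, how an amine or a carboxylic acid on this carbon would compare also remains open.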